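Chloro in Place of Bromo: Expected Outcome for Compound 3

The source may report more compounds than this note shows. Statements on the series, on what has been measured and on what is new or still open speak of the compounds shown alone.

Measured compounds:
compound 1, `O=C1CSC(N2N=C(c3ccc(Br)cc3)CC2c2ccc3ccccc3c2)=N1`, 11700 nM in a functional assay on BGC-823 cells (Homo sapiens) for inhibition, read by CCK-8 assay, with a stated time of 48 h; on this read-out lower numbers stand for stronger inhibition and higher numbers for weaker inhibition
compound 2, `Brc1ccc(C2=NN(C3=NC(c4ccccc4)CS3)C(c3ccc4ccccc4c3)C2)cc1`, 13000 nM

In this assay compound 1 gives 11700 nM, and compound 2 gives 13000 nM. Compound 1 holds the lowest of the two numbers, with compound 2 nearest to it, the pair being separated only by a 1.1-fold higher number from compound 1 to compound 2 (0.05 log units; within the scatter), a step that concerns the group on the amine nitrogen in a ring and not the halogen.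

Compound 3 `O=C1CSC(N2N=C(c3ccc(Cl)cc3)CC2c2ccc3ccccc3c2)=N1` differs from compound 1 by chloro in place of bromo on an aromatic carbon. For the measured compounds named here, no measured step touches this position, so the only step known, a 1.1-fold higher number from compound 1 to compound 2 (0.05 log units; within the scatter), bears on it merely as a sign that a substantial change elsewhere on the shared core left the number where it was. Chloro and bromo are both single heavy atoms on the same aromatic carbon, and no compound here shows what the exchange does. Compound 3 is therefore expected to stay within the scatter of compound 1, with the step of a 1.1-fold higher number from compound 1 to compound 3 (0.05 log units; within the scatter) estimated as no more than noise. The estimate for compound 3 is 13000 nM, with a range from 5500 nM to 32000 nM.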

Compound 3, half-maximal inhibitory concentration: 13200 nM
Estimate against measurement, compound 3: 1.0-fold (0.01 log units) below; the measured number falls inside the stated range.
By their numbers in this assay, from the lowest: compounds 1, 2 and 3 (each within the scatter of the next).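

In this assay, chloro in place of bromo on the aromatic carbon, para to a large group, gives a 1.1-fold higher number from compound 1 to compound 3 (0.05 log units; within the scatter), and this is the only reading of this position among the compounds shown. Where the earlier pair spoke only to the group on the amine nitrogen in a ring, this pair shows that 4-bromophenyl and 4-chlorophenyl cannot be told apart on this read-out when the rest of compound 1 is held constant. No evidence is available on why the two halogens give results within the scatter of each other.

Both groups at this position are halogens, so the compounds shown leave open whether a halogen is needed there at all, or whether a methoxy group, an amine or a carboxylic acid on the same aromatic carbon would keep the number within the scatter of compound 1. They also leave open whether chloro in place of bromo would read the same way on compound 2, which carries the other group on the amine nitrogen in a ring.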